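Swapping a methyl for a cyano on the benzyl ether

The source may hold more compounds than are shown below. What is called first, only, known or untested is meant among the compounds shown, and "the series" means these compounds.

Compound 1 `O=C1CCCc2cc(OCc3cccc(Cl)c3)ccc21`: 207 nM
Compound 2 `O=C1CCCc2cc(OCc3ccc(Br)cc3)ccc21`: 311 nM
Compound 3 `Cc1ccc(COc2ccc3c(c2)CCCC3=O)cc1`: 2090 nM

Three compounds share one core and differ only in the group on the outer benzene ring. In an assay on isolated protein for inhibition of Amine oxidase [flavin-containing] A (Homo sapiens), read by fluorescence and spectrophotometry, with a stated time of 30 min (a higher number here means a weaker inhibitor, a lower number a stronger inhibitor), compound 1 gives 207 nM with chloro, compound 2 gives 311 nM with bromo, and compound 3 gives 2090 nM with methyl, the highest number of the three and so the weakest inhibitor shown. Among the compounds with values here, the one single-point step that has been measured is a 6.7-fold higher number from compound 2 to compound 3 (0.83 log units; beyond the scatter).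

Compound 4 `N#Cc1ccc(COc2ccc3c(c2)CCCC3=O)cc1` is the next member, not yet measured. It differs from compound 3 by cyano in place of methyl on an aromatic carbon. Within the data shown here, no measured step involves a cyano, so the only guidance is that bromo and chloro both gave clearly lower numbers than methyl, while the direction for cyano is open. The expectation is therefore a moderate move back toward the halogen values, but with wide uncertainty: the estimated step is a 2.1-fold lower number from compound 3 to compound 4 (0.32 log units; beyond the scatter). Compound 4 is expected to give about 1000 nM in this assay, within a range from 250 nM to 4000 nM.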

Compound 4, half-maximal inhibitory concentration: 656 nM
Compound 4: middle estimate off by 1.5-fold (0.18 log units), on the high side, within the range that was stated.
By their numbers in this assay, from the lowest: compounds 1 and 2 (each within the scatter of the next); then compound 4; then compound 3.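

The position tolerates more than a choice between halogen and methyl: replacing methyl with cyano, a group with a nitrogen and a triple bond, gives a 3.2-fold lower number from compound 3 to compound 4 (0.50 log units; beyond the scatter) and recovers part of the gap that separated methyl from bromo. Cyano does not close that gap, however, as the comparison with bromo shows a 2.1-fold higher number from compound 2 to compound 4 (0.32 log units; beyond the scatter) and places cyano between the two earlier groups, with each step beyond the scatter. Nothing available here explains why these three groups fall in this order.

As far as these compounds go, it remains open where a methoxy group, a trifluoromethyl group, a carboxylic acid or a plain hydrogen would fall at this position. Also open, from the compounds shown here alone, is whether cyano would hold the same rank elsewhere on the outer benzene ring.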